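Working notes: a side-chain swap at the weak end

The compounds below may be only part of what the source reports. "The series", "measured", "known", "first", "only" and "open" are said of these compounds alone.

Measured so far:
compound 1, `OCc1ccc(-c2nn(Cc3ccccc3F)c3cnccc23)o1`; in a functional assay (aorta) with Oryctolagus cuniculus as the target (a higher number here means a weaker inhibitor, a lower number a stronger inhibitor), compound 1 gives 6930 nM
compound 2, `Cc1coc(-c2nn(Cc3ccccc3F)c3ncccc23)n1`; in this assay compound 2 gives 1200 nM
compound 3, `CCCCc1cnc(-c2nn(Cc3ccccc3F)c3ncccc23)nc1N`; in this assay compound 3 gives 218000 nM

Compound 3 stands highest of the three numbers in this assay, beyond the scatter from both others; compound 1 is the nearest of them and compound 2 the furthest. Among the measured compounds shown here, no pair here differs in a single place, so no measured step is available to guide the next one.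

Compound 4, `N#CCCc1cnc(-c2nn(Cc3ccccc3F)c3ncccc23)nc1N`, is compound 3 with one change: cyano in place of ethyl on a saturated chain carbon, two bonds along the chain from an aromatic carbon. No comparable swap has been measured in this set. The expected step from compound 3 to compound 4 in this assay is a 1.5-fold lower number from compound 3 to compound 4 (0.16 log units; within the scatter), small and toward a lower number, not clearly beyond the scatter. Compound 4 is expected to give about 150000 nM, within 50000 nM to 450000 nM.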

Compound 4, half-maximal inhibitory concentration: 412000 nM
Estimate against measurement, compound 4: 2.7-fold (0.44 log units) below; measured number inside the range.
By their numbers in this assay, from the lowest: compound 2; then compound 1; then compounds 3 and 4 (each within the scatter of the next).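

Among the compounds shown here, this is the first single-place step. Cyano in place of ethyl, on a saturated chain carbon two bonds along the chain from an aromatic carbon, gives a 1.9-fold higher number from compound 3 to compound 4 (0.28 log units; within the scatter) in this assay. At this position, the butyl and 2-cyanoethyl chains cannot be told apart in this read-out, and no measured property bears on the result.

Still open, as far as these compounds go, is whether an amine, a carboxylic acid or a longer chain at this place would move the number beyond the scatter. For the compounds shown here, no single-place step yet links this pair to compound 1 or compound 2.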